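Double-bond geometry swap within the butyl-phenyl alkyne pair

This account rests on a few compounds, and the source may have more. Where it says the series, first, only, none or still open, it means among the compounds named here.

Compound 2 `CCCCc1ccc(C#Cc2cn(C/C=C/CN3C(=O)c4ccccc4C3=O)c(=O)[nH]c2=O)cc1` is compared in a functional assay on HepG2 cells (Homo sapiens) for antiproliferative activity, read by MTT assay, with a stated time of 3 days (on this read-out higher numbers stand for weaker inhibition and lower numbers for stronger inhibition), with compound 1 `CCCCCc1ccc(C#Cc2cn(C/C=C\CN3C(=O)c4ccccc4C3=O)c(=O)[nH]c2=O)cc1`. In this assay compound 2 gives 9100 nM and compound 1 gives 18000 nM; the two numbers lie within the usual scatter of each other, so neither stands apart. Compound 3 `CCCCc1ccc(C#Cc2cn(C/C=C\CN3C(=O)c4ccccc4C3=O)c(=O)[nH]c2=O)cc1` is not yet measured; relative to compound 2, (the two compounds have the same atoms and bonds and differ only in configuration as drawn: 1 of 1 stereo elements differ; a double bond is drawn E in compound 2 and Z in compound 3). Among the compounds with values here, no step of this kind has been measured here, so the change is expected to stay within the scatter or move slightly toward weaker inhibition. Compound 3 is expected at 14000 nM (6000 nM to 35000 nM), meaning a 1.5-fold higher number from compound 2 to compound 3 (0.19 log units; within the scatter). This rests on compound 1, which gives 18000 nM with the same drawn Z double bond.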

Compound 3, half-maximal inhibitory concentration: 40000 nM
Beside the measured number, compound 3's estimate is 2.9-fold (0.46 log units) below it, outside the stated range (above it).
By their numbers in this assay, from the lowest: compounds 2 and 1 (each within the scatter of the next); then compound 3.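

Setting the double bond Z rather than E gives a 4.4-fold higher number from compound 2 to compound 3 (0.64 log units; beyond the scatter) in this assay, so geometry at this linker matters on this read-out. That step can be assigned to configuration alone: the fact that compounds 2 and 3 differ only in the configuration as drawn. Within the Z pair, hydrogen in place of methyl on a saturated chain carbon gives a 2.2-fold higher number from compound 1 to compound 3 (0.35 log units; beyond the scatter), so the chain end also counts.

As far as these compounds go, whether the E double bond keeps its advantage with the longer chain of compound 1 stays open. So does the effect of a hexyl chain or a terminal amine on that chain.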